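A few compounds are considered here, and "the series" means these few. Any claim that something is new, unique, unknown or untested is made for them only; others in the source may bear on it.

Measured so far:
compound 1, `O=C(Cc1ccncc1)c1cc2ccccc2[nH]1`, in an in vitro assay on P815B cells for inhibition of Indoleamine 2,3-dioxygenase 1 (Mus musculus), tested at 20 uM (a lower number here means less inhibition, a higher number more inhibition at the concentration tested (going by the name of the read-out)), compound 1 gives "not active" (no number reported)
compound 2, `O=C(Cc1cccnc1)c1cc2cc(Cl)ccc2[nH]1`, in this assay compound 2 gives 24%
compound 3, `O=C(Cc1cccnc1)c1[nH]c2ccccc2c1Br`, in this assay compound 3 gives "not active" (no number reported)

Compound 2 stands as the only one of the three with a reported number in this assay; the other two entries carry no number. Compound 4, `O=C(Cc1cccnc1)c1cc2cc(OC(F)(F)F)ccc2[nH]1`, has not yet been measured. It differs from compound 2 in one place: trifluoromethoxy in place of chloro on an aromatic carbon. Within the data shown here, no step between two measured compounds is available to gauge what such a change does here. The expected step in this assay from compound 2 to compound 4 is therefore none beyond the usual scatter, a number 4 percentage points lower from compound 2 to compound 4 (within the scatter). Compound 4 is estimated to give 20%, within a range from 3% to 38%, resting only on the value of compound 2, 24%.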

Compound 4, a percentage reported as inhibition, at one concentration (the size of the read-out at that concentration, not a potency): 12%
Compound 4: middle estimate off by 8 percentage points, on the high side; measured number inside the range.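

Trifluoromethoxy in place of chloro on this aromatic carbon gives, in this assay, a number 12 percentage points lower from compound 2 to compound 4 (beyond the scatter), the first step that can be read at this position. It shows that the inhibition at the concentration tested responds to the group placed here, and that the larger group still leaves compound 4 with a reported number. Nothing available explains the direction of this step. The compounds shown leave open how an amine, a carboxylic acid or a longer alkyl chain on this carbon would read out. They also leave open whether the same exchange would give a similar step on the core of compound 1.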